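From Methoxy to Bromo: Estimating a Cytotoxicity Value

A few compounds are considered here, and "the series" means these few. Any claim that something is new, unique, unknown or untested is made for them only; others in the source may bear on it.

In a functional assay on MT4 cells (Homo sapiens) for cytotoxicity, read by MTT assay (a lower number here means that less compound is tolerated, a higher number that more compound is tolerated), compound 1 `Cc1c(O)nc(S(=O)(=O)Cc2ccc([N+](=O)[O-])cc2)nc1Cc1c(Cl)cccc1Cl` gives > 53000 nM, which is a limit of the assay and not a number. Going by the values given here, compound 2 `COc1ccc(CS(=O)(=O)c2nc(O)c(C)c(Cc3c(Cl)cccc3Cl)n2)cc1` gives 2800 nM, the only actual number so far.

Among the compounds with values here, the only measured step here is the swap of nitro for methoxy on an aromatic carbon, which gave an at least 18-fold lower number from compound 1 to compound 2 (1.27 log units; beyond the scatter). That large step shows that the group on this aromatic carbon can shift the tolerated concentration strongly.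

Compound 3 `Cc1c(O)nc(S(=O)(=O)Cc2ccc(Br)cc2)nc1Cc1c(Cl)cccc1Cl` keeps everything else and carries bromo in place of methoxy on that aromatic carbon (bromo in place of methoxy on an aromatic carbon). Bromo matches neither group already measured, so a single step offers only a rough guide. With compound 2 at 2800 nM as the starting point, a moderate move towards a higher number seems likely, smaller than the step seen before, though no change at all remains possible. The expected size of this move is a 3.2-fold higher number from compound 2 to compound 3 (0.51 log units; beyond the scatter). The estimated value for compound 3 is 9000 nM, with an expected range from 2500 nM to 35000 nM.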

Compound 3, half-maximal cytotoxic concentration: > 50000 nM
Compound 3 ended at the assay's limit; the forecaster's own chance of this, stated with the estimate: 25%; middle value at least 5.5-fold (0.74 log units) from the limit.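

In this assay compound 3 ends at a limit and not at a number: the limit of > 50000 nM in this assay, at which 1 of the 3 values shown sits.

Going by these compounds alone, putting bromo in place of methoxy on this aromatic carbon gives an at least 17-fold higher number from compound 2 to compound 3 (1.25 log units; beyond the scatter), a large step that the earlier compounds gave no sign of for this group. Of the three groups shown on this carbon, methoxy is now the only one that gives an actual number, while nitro and bromo, which have no atom in common, both end at a limit, so the earlier step can no longer be read as a feature of nitro alone. The step between compound 1 and compound 3 cannot be read, since each of the two compounds ends at a limit of the assay.

As far as these compounds go, how far compound 3 lies past its limit stays unknown, and these compounds cannot tell which feature of methoxy goes with the lower number. From the compounds shown here alone, whether an ethoxy group, a hydroxy group or an amine on the same carbon would behave like methoxy, or like nitro and bromo, also remains open.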